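Moving the fluorine: from 2-fluorophenyl to 4-fluorophenyl

This account rests on a few compounds, and the source may have more. Where it says the series, first, only, none or still open, it means among the compounds named here.

Going by the values given here, in a functional assay on HepG2 cells (Homo sapiens) for cytotoxicity, read by MTT assay, with a stated time of 24 h (a higher number here means a weaker inhibitor, a lower number a stronger inhibitor), compound 1 (`COc1cc(/C=C2\CN(C)C/C(=C\c3ccccc3F)C2=O)cc(OC)c1`) gives 1240 nM, the higher of only two numbers so far. Compound 2 (`COc1cc(/C=C2\CN(C)C/C(=C\c3ccccc3F)C2=O)cc(OC)c1OC`) gives 670 nM, and the two lie within the scatter of each other. Compound 3 (`COc1cc(/C=C2\CN(C)C/C(=C\c3ccc(F)cc3)C2=O)cc(OC)c1`) has not yet been measured. Its change from compound 1 is 4-fluorophenyl in place of 2-fluorophenyl on a double-bonded chain carbon bound to a double-bonded ring carbon. Among the compounds with values here, the only measured step, a 1.9-fold lower number from compound 1 to compound 2 (0.27 log units; within the scatter), is methoxy in place of hydrogen on an aromatic carbon, so it bears on this change only indirectly. Within the data shown here, no measured pair shows a fluorine moved, so the data give no direction, and no step beyond the scatter is expected in this assay. The estimate implies an expected 1.1-fold lower number from compound 1 to compound 3 (0.05 log units; within the scatter). For compound 3 the expected value is 1100 nM, with an estimated range of 450 nM to 2700 nM.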

Compound 3, half-maximal inhibitory concentration: 6140 nM
For compound 3 the middle estimate is 5.6-fold (0.75 log units) below the measured one; measured number outside the range, above it.
By their numbers in this assay, from the lowest: compounds 2 and 1 (each within the scatter of the next); then compound 3.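

Moving the fluorine matters in this assay: 4-fluorophenyl in place of 2-fluorophenyl on a double-bonded chain carbon bound to a double-bonded ring carbon gives a 5.0-fold higher number from compound 1 to compound 3 (0.69 log units; beyond the scatter) and this is the only step so far beyond the scatter. The two groups have the same atoms and the same counts, so this position responds to where the fluorine sits on the phenyl ring and not only to which atoms are present, with the 4-fluorophenyl group giving the weaker inhibitor of this pair. Nothing at hand gives a reason for the difference.

The compounds shown cannot tell whether a plain phenyl or a 3-fluorophenyl group at this carbon would resemble compound 1 or compound 3. They also leave open whether the same move of the fluorine would have a similar effect on the core of compound 2.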